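Trimming the Isobutyl Chain of Compound 1 to Propyl

The source may report more compounds than this note shows. Statements on the series, on what has been measured and on what is new or still open speak of the compounds shown alone.

In a functional assay on MCF7 cells (Homo sapiens) for antiproliferative activity, read by CCK-8 assay, with a stated time of 72 h (a lower number here means a stronger inhibitor of growth, a higher number a weaker inhibitor of growth), compound 1 `CCC1C(=O)N(C)c2cnc(Nc3ccc(S(=O)(=O)NCC(C)C)cc3)nc2N1c1ccn(C)n1` gives 8350 nM, while compound 2 `CCC1C(=O)N(C)c2cnc(-n3ccc4cc(C(=O)NC)ccc43)nc2N1c1ccn(C)n1` gives 35400 nM. Compound 1 therefore has the lower of the two numbers, and the gap lies beyond the usual scatter. Compound 3 `CCCNS(=O)(=O)c1ccc(Nc2ncc3c(n2)N(c2ccn(C)n2)C(CC)C(=O)N3C)cc1` has not yet been measured. It keeps the core of compound 1 and differs in one place: hydrogen in place of methyl on a saturated chain carbon bound to two saturated chain carbons. Hydrogen stands in place of methyl on a saturated chain carbon bound to two saturated chain carbons, turning isobutylamino into propylamino. Going by the values given here, no measured pair yet tests this chain, so no step beyond the scatter is expected in this assay, and neither direction is favoured. The expected step is a 1.0-fold lower number from compound 1 to compound 3 (0.02 log units; within the scatter). For compound 3 the estimated value is 8000 nM, with an expected range of 3500 nM to 18000 nM.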

Compound 3, concentration for 50% growth inhibition: 3000 nM
The estimate for compound 3 lay 2.7-fold (0.43 log units) above the measured number, outside the stated range (below it).
By their numbers in this assay, from the lowest: compound 3; then compound 1; then compound 2.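

Compound 3 gives the first measured test of this chain in this assay: turning isobutylamino into propylamino gives a 2.8-fold lower number from compound 1 to compound 3 (0.44 log units; beyond the scatter), so this position does respond to the change. Only a methyl leaves and a hydrogen enters, with no ring, hydrogen-bond donor, hydrogen-bond acceptor or net charge involved, yet this small edit on a saturated chain carbon bound to two saturated chain carbons moves the number beyond the scatter. Nothing available explains why the propyl chain gives the lower number. 

From the compounds shown here alone, it remains open whether an ethyl chain, a longer butyl chain or a chain carrying an amine would lower the number further. This is also a single step on the core of compound 1, so it cannot show whether the same edit would have a similar effect on another core.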